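Trimming the Sulfamide of Compound 2 for Compound 4

The source may hold more compounds than are shown below. What is called first, only, known or untested is meant among the compounds shown, and "the series" means these compounds.

The series shares one core, seen in compound 1 `CCN1CCCC1CNC(=O)c1cc(NS(=O)(=O)N(C)C)ccc1OC`, which in a functional assay on the whole organism for inhibition, with Canis familiaris (Canis lupus familiaris) as the target (on this read-out higher numbers stand for an effect only at larger amounts of compound and lower numbers for an effect already at smaller amounts), gives 1 mg/kg. Compound 2 `CCN1CCCC1CNC(=O)c1cc(N(C)S(=O)(=O)N(C)C)ccc1OC` gives 1 mg/kg in this assay, level with compound 1 and together with it the highest of the three numbers; the furthest is compound 3 `CCN1CCCC1CNC(=O)c1cc(N(C)S(=O)(=O)N(C)C)c(Cl)cc1OC`, which gives 0.1 mg/kg in this assay. The step of a 10-fold lower number from compound 2 to compound 3 (1.00 log units; beyond the scatter) is the only one beyond the scatter.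

Compound 4 `CCN1CCCC1CNC(=O)c1cc(NS(=O)(=O)NC)ccc1OC` differs from compound 2 by (methylsulfamoyl)amino in place of (dimethylsulfamoyl)(methyl)amino on an aromatic carbon. Among the compounds with values here, the only measured step that touches this position is no change at the digits printed from compound 1 to compound 2 (within the scatter), and it stayed within the scatter, so the methyl on the sulfonamide nitrogen did not matter there. Within the data shown here, no measured pair removes a methyl from the sulfamoyl end itself, so that part of the change stands without precedent. On this basis compound 4 is expected to stay near compound 2, with an expected step of no change at the digits printed from compound 2 to compound 4 (within the scatter). The estimate for compound 4 in this assay is 1 mg/kg, within 0.4 mg/kg to 3 mg/kg.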

Compound 4, dose for half-maximal effect: > 1 mg/kg
Compound 4 ended at the assay's limit; the forecaster's own chance of this, stated with the estimate: 10%; the middle value lies on the limit itself.
By their numbers in this assay, from the lowest: compound 3; then compounds 1 and 2 (each within the scatter of the next).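

In this assay compound 4 gives > 1 mg/kg, a limit of the assay and not a number. Hydrogen in place of methyl on a sulfonamide nitrogen gives a number no lower from compound 1 to compound 4 (the limit leaves the size open), and (methylsulfamoyl)amino in place of (dimethylsulfamoyl)(methyl)amino gives a number no lower from compound 2 to compound 4 (the limit leaves the size open). Within the data shown here, neither step can be read in size, yet they give the first look at the sulfamoyl end of this group, whereas the earlier change at this position gave no change at the digits printed from compound 1 to compound 2 (within the scatter). The result therefore adds a direction but no size, and it sits at the edge of the values shown: the limit of > 1 mg/kg in this assay, at which 1 of the 4 values shown sits.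

On these data alone, how far compound 4 lies from compound 1 stays open. So does whether a longer chain such as ethyl, or a primary amine, on the sulfamoyl end would give a readable number in this assay.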